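A few compounds are considered here, and "the series" means these few. Any claim that something is new, unique, unknown or untested is made for them only; others in the source may bear on it.

Measured compounds in a functional assay on A549 cells (Homo sapiens) for cytotoxicity, read by MTT assay, with a stated time of 48 h; on this read-out higher numbers stand for weaker inhibition and lower numbers for stronger inhibition:
- Compound 1, `COc1ccc(-c2cc(C(=O)Nc3nc4ccc(F)cc4s3)nc3cc(-c4ccccc4)nn23)cc1OC`: 6910 nM
- Compound 2, `COc1cc(-c2cc(C(=O)Nc3nc4ccc(F)cc4s3)nc3cc(-c4ccccc4)nn23)cc(OC)c1OC`: 22400 nM
- Compound 3, `COc1ccc(-c2cc(C(=O)Nc3nc4ccccc4s3)nc3cc(-c4ccccc4)nn23)cc1`: 1540 nM

Compound 3 carries the lowest number of the three; compound 1 and compound 2 both stand beyond its scatter. The difference between the core of compound 3 and the core of compound 1 is not broken down here.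

One change has been measured once: from compound 1 to compound 2 the change is methoxy in place of hydrogen on an aromatic carbon and the step is a 3.2-fold higher number from compound 1 to compound 2 (0.51 log units; beyond the scatter).

Compound 4, `COc1ccc(-c2cc(C(=O)Nc3nc4ccccc4s3)nc3cc(-c4ccccc4)nn23)cc1OC`, is not yet measured in this assay. It derives from compound 3 by methoxy in place of hydrogen on an aromatic carbon. Among the compounds with values here, this is the same kind of change as the one from compound 1 to compound 2, not the same: in compound 2 the entering methoxy is also meta to a methoxy group, whereas in compound 4 it is not.

Within the data shown here, for compound 4 a step of similar direction and size is expected, a 2.6-fold higher number from compound 3 to compound 4 (0.41 log units; beyond the scatter), because the only measured instance of this kind of change gave a 3.2-fold higher number from compound 1 to compound 2 (0.51 log units; beyond the scatter). This rests on a single pair, so the expectation is loose. Compound 4 is estimated at 4000 nM in this assay, with a range from 1500 nM to 10000 nM.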

Compound 4, half-maximal inhibitory concentration: 5490 nM
Beside the measured number, compound 4's estimate is 1.4-fold (0.14 log units) below it; measured number inside the range.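

In this assay the change from 4-methoxyphenyl to 3,4-dimethoxyphenyl gives a 3.6-fold higher number from compound 3 to compound 4 (0.55 log units; beyond the scatter), and the added methoxy carries across the two cores at much the same size: the same change on two cores in this assay, a 3.2-fold higher number (0.51 log units; beyond the scatter) from compound 1 to compound 2 and a 3.6-fold higher number (0.55 log units; beyond the scatter) from compound 3 to compound 4, 1.1-fold (0.04 log units) apart, within the scatter of two such steps. The swap of hydrogen for fluoro on an aromatic carbon gives a 1.3-fold lower number from compound 1 to compound 4 (0.10 log units; within the scatter), so this pair shows no readable effect of the fluoro group in compounds that carry the 3,4-dimethoxyphenyl group. Within the data shown here, these are only two pairs in one assay, and the methoxy enters a different substitution pattern on each core, so the notes do not show that the step would hold on further cores or with other aryl groups.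

Still open, on these data alone, is whether a hydroxy group, an amine or a longer alkoxy chain in place of the entering methoxy would move the number in the same way. Also open, as far as these compounds go, is whether chloro in place of fluoro would leave the number as close as fluoro does.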